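A few compounds are considered here, and "the series" means these few. Any claim that something is new, unique, unknown or untested is made for them only; others in the source may bear on it.

Working notes on the series, read in a toxicity assay on HepG2 2.2.15 cells (Homo sapiens) for cytotoxicity, read by CellTiter-Glo; on this read-out higher numbers stand for lower toxicity in this test and lower numbers for higher toxicity in this test. Compound 3 (`O=C1CC(C(F)(F)F)CN1c1cnn2c1CN(C(=O)Nc1cc(F)c(F)c(F)c1)C(C1CC1)C2`) gives 115000 nM and compound 2 (`O=C1CC(Oc2ncc(F)cn2)CN1c1cnn2c1CN(C(=O)Nc1cc(F)c(F)c(F)c1)C(C1CC1)C2`) gives 96200 nM, so the two are level within the scatter. Compound 1 (`O=C1CC(c2cnc(C(F)(F)F)s2)CN1c1cnn2c1CN(C(=O)Nc1cc(F)c(F)c(F)c1)C(C1CC1)C2`) gives 38500 nM, and the other two both stand clear of it.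

Compound 4 (`O=C1CC(c2cnco2)CN1c1cnn2c1CN(C(=O)Nc1cc(F)c(F)c(F)c1)C(C1CC1)C2`) carries 1,3-oxazol-5-yl in place of trifluoromethyl on a saturated ring carbon.

Among the compounds with values here, two measured steps bear on this change. Replacing trifluoromethyl with the (5-fluoropyrimidin-2-yl)oxy group of compound 2 costs nothing beyond the scatter, as a 1.2-fold higher number from compound 2 to compound 3 (0.08 log units; within the scatter) shows. The 2-(trifluoromethyl)-1,3-thiazol-5-yl group of compound 1 marks the larger case, with a 3.0-fold higher number from compound 1 to compound 3 (0.48 log units; beyond the scatter), a modest step. Also modest is a 2.5-fold higher number from compound 1 to compound 2 (0.40 log units; beyond the scatter).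

Within the data shown here, the data hold no oxazole precedent, so the expectation falls between these two cases, leaning towards lower numbers. The expected step is a 1.4-fold lower number from compound 3 to compound 4 (0.16 log units; within the scatter), which would stay within the scatter. For compound 4 the estimated value is 80000 nM, with an expected range of 40000 nM to 140000 nM.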

Compound 4, half-maximal cytotoxic concentration: 139000 nM
The estimate for compound 4 lay 1.7-fold (0.24 log units) below the measured number, and the stated range covers the measured number.
By their numbers in this assay, from the lowest: compound 1; then compounds 2, 3 and 4 (each within the scatter of the next).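

In this assay the top of the series now holds three different groups on this saturated ring carbon, since 1,3-oxazol-5-yl stays level with trifluoromethyl (a 1.2-fold higher number from compound 3 to compound 4 (0.08 log units; within the scatter)) and with (5-fluoropyrimidin-2-yl)oxy (a 1.4-fold higher number from compound 2 to compound 4 (0.16 log units; within the scatter)). A five-membered aromatic ring at this place therefore does not by itself bring the low number of compound 1, and the pair differs clearly (a 3.6-fold higher number from compound 1 to compound 4 (0.56 log units; beyond the scatter)). No measurement on hand accounts for the level numbers or for the gap to compound 1.

Open, from the compounds shown here alone, is whether the plain 1,3-thiazol-5-yl group, without its trifluoromethyl, would read with compound 1 or with compound 4. Also open, going by these compounds, is how a primary amine or a carboxylic acid on this carbon would read.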